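Sulfonate ureas: trimming the chloropropyl chain

The source may report more compounds than this note shows. Statements on the series, on what has been measured and on what is new or still open speak of the compounds shown alone.

The series rests on a shared core in which an aryl sulfonate carries a urea-bearing aniline. Compound 1 `CCc1ccccc1OS(=O)(=O)c1ccc(NC(=O)NCCCCl)cc1` gives 15000 nM in a functional assay on M21 cells (Homo sapiens) for cytotoxicity, read by sulforhodamine B assay, with a stated time of 48 h; on this read-out lower numbers stand for stronger inhibition and higher numbers for weaker inhibition. For the measured compounds named here, compound 2 `O=C(NCCCCl)Nc1ccc(S(=O)(=O)Oc2ccc(O)cc2)cc1` gives 47000 nM in the same assay; the single change, 4-hydroxyphenyl in place of 2-ethylphenyl on an oxygen, reads as a 3.1-fold higher number from compound 1 to compound 2 (0.50 log units; beyond the scatter). Going by the values given here, compound 1 thus stands as the lowest of the two numbers so far, with compound 2 the only neighbour.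

Compound 3 `CCNC(=O)Nc1ccc(S(=O)(=O)Oc2ccccc2CC)cc1` keeps the 2-ethylphenyl side of compound 1 and alters the urea chain instead: hydrogen in place of chloromethyl on a saturated chain carbon, two bonds along the chain from an amide-type nitrogen, so that the (3-chloropropyl)amino end becomes ethylamino. Among the compounds with values here, no measured step touches this chain; the only step on record, from compound 1 to compound 2, concerns the aryl on oxygen and is modest. The expectation for compound 3 therefore rests on little, and a wide range is kept. A step toward a higher number is expected, a 3.0-fold higher number from compound 1 to compound 3 (0.48 log units; beyond the scatter), with compound 3 estimated at 45000 nM (range 12000 nM to 200000 nM).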

Compound 3, half-maximal inhibitory concentration: 2500 nM
Beside the measured number, compound 3's estimate is 18-fold (1.26 log units) above it; the measured number lies below the stated range.
By their numbers in this assay, from the lowest: compound 3; then compound 1; then compound 2.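

The urea chain is a position where the number in this assay moves, and the step of a 6.0-fold lower number from compound 1 to compound 3 (0.78 log units; beyond the scatter) shows that the (3-chloropropyl)amino end of compound 1 is not required for activity, since ethylamino in compound 3 goes with stronger inhibition. The only earlier step, a 3.1-fold higher number from compound 1 to compound 2 (0.50 log units; beyond the scatter) on the aryl on oxygen, went toward weaker inhibition, so compound 3 is the first change shown to lower the number from compound 1. The change removes chlorine and shortens the chain in one move, and no measurement at hand explains the lower number or says which of the two goes with it.

Still open, going by these compounds, is whether the lower number follows the loss of chlorine or the shorter chain, which an unsubstituted propyl chain on the urea would help to separate, and how far the trend runs with a methyl group or a longer chain ending in an amine or a carboxylic acid. Also open, on these data alone, is whether ethylamino gives a step of similar direction on the 4-hydroxyphenyl side of compound 2.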